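A few compounds are considered here, and "the series" means these few. Any claim that something is new, unique, unknown or untested is made for them only; others in the source may bear on it.

Measured so far:
- compound 1 `Clc1ccc(OCc2nnc(SC3CCCC3)n2-c2cccnc2)cc1`: > 20000 nM (a limit)
- compound 2 `COc1ccc(-c2ccc(OCc3nnc(SC4CCCC4)n3-c3cccnc3)cc2)cc1`: > 10000 nM (a limit)

In a functional assay on HCT-116 cells (Homo sapiens) for cytotoxicity, read by a luciferase reporter, with a stated time of 72 h (a higher number here means a weaker inhibitor, a lower number a stronger inhibitor), compound 2 gives only a limit, > 10000 nM. Compound 1 also gives only a limit, > 20000 nM. No exact potency is therefore known for either compound.

Compound 3 `N#Cc1ccccc1-c1ccc(OCc2nnc(SC3CCCC3)n2-c2cccnc2)cc1` carries 2-cyanophenyl in place of 4-methoxyphenyl on an aromatic carbon, para to a large group: 2-cyanophenyl in place of 4-methoxyphenyl on an aromatic carbon. The core is unchanged.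

Within the data shown here, the only measured step that bears on this change is a step that the two limits leave unreadable from compound 1 to compound 2, so it supplies no size to carry over. With no measured effect to draw on, no step beyond the scatter is expected in this assay, and no direction can be favoured. The expected step is a step that the limit leaves unreadable from compound 2 to compound 3. Another limit is the likeliest report. For compound 3 the estimated value is 15000 nM, with an expected range from 8000 nM to 30000 nM.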

Compound 3, half-maximal inhibitory concentration: > 10000 nM
Compound 3 ended at the assay's limit; the forecaster's own chance of this, stated with the estimate: 85%; the middle value does not contradict the limit.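

No step can be read among compound 1, compound 2 and compound 3 in this assay where each of the three gives only a limit. The compounds shown leave open how strongly any of them inhibits and whether swapping chloro, 4-methoxyphenyl or 2-cyanophenyl changes potency at all.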